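A methylsulfanyl group in place of methoxy: the expected dose

The source may hold more compounds than are shown below. What is called first, only, known or untested is meant among the compounds shown, and "the series" means these compounds.

Of the compounds shown here, three have been tested in a functional assay on the whole organism (strain Sprague-Dawley) for inhibition, with Rattus norvegicus as the target; a higher number here means that more compound is needed for the effect, a lower number that less compound is needed. Compound 1 `CCc1cccc2cc(C(=O)O)cnc12` gives > 50 mg/kg, which is a limit of the assay rather than a number, and it is the compound that sits at the limit of > 50 mg/kg in this assay, at which 1 of the 3 values shown sits. Compound 3 `O=c1c(-c2nn[nH]n2)c[nH]c2ccc(Cl)cc12` gives > 10 mg/kg, again a limit and not a number, and it is the compound that sits at the limit of > 10 mg/kg in this assay, at which 1 of the 3 values shown sits. Among the measured compounds shown here, compound 2 `COc1cccc2c(=O)c(-c3nn[nH]n3)c[nH]c12` is different: in this assay compound 2 gives 0.15 mg/kg, and this is the only actual number among the three results.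

Compound 4 `CSc1cccc2c(=O)c(-c3nn[nH]n3)c[nH]c12` has not yet been measured. It differs from compound 2 in one place only: methylsulfanyl in place of methoxy on an aromatic carbon. For the measured compounds named here, no measured pair among the three compounds shows what such an exchange does, so the size of the step can only be estimated. Sulfur and oxygen are both counted as a single heavy atom here with one hydrogen-bond acceptor each, so the step from compound 2 to compound 4 is expected to be small, a 2.0-fold higher number from compound 2 to compound 4 (0.30 log units; within the scatter), at most slightly toward a higher dose and close to the usual scatter. Compound 4 is therefore expected to need about 0.3 mg/kg, with a likely range from 0.1 mg/kg to 1.5 mg/kg.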

Compound 4, minimum effective dose: 10 mg/kg
Compound 4: the middle estimate sits 33-fold (1.52 log units) below what was measured; measured number outside the range, above it.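

The pair of compound 2 and compound 4 is the only one here that isolates a single change, and it shows that this position on the aromatic ring is sensitive to a small exchange: in this assay, replacing methoxy with methylsulfanyl gives a 67-fold higher number from compound 2 to compound 4 (1.82 log units; beyond the scatter). The two groups have the same counts of heavy atoms, hydrogen-bond donors and hydrogen-bond acceptors, and neither carries a net charge, so these simple counts do not predict the size of this step. Nothing measured here accounts for why swapping oxygen for sulfur at this place matters so much.

As far as these compounds go, it remains open whether a longer chain such as ethoxy, a hydroxyl group or an amine on the same aromatic carbon would keep the low dose of compound 2 or shift it as methylsulfanyl does. From the compounds shown here alone, with a single pair, it also remains open whether the same exchange would produce a step of similar size at another place on the shared core.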